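This account rests on a few compounds, and the source may have more. Where it says the series, first, only, none or still open, it means among the compounds named here.

The series shares the core seen in compound 1 `NC(=S)Nc1cccc(OCCCCCOc2ccc(F)cc2)c1` and compound 2 `NC(=S)Nc1cccc(OCCCCCOc2ccc(Br)cc2)c1`, which differ only at one aromatic carbon. In an ADME assay on Ava5 cells (Homo sapiens) for cytotoxicity (a higher number here means that more compound is tolerated, a lower number that less compound is tolerated), compound 1 gives 5000 nM, while compound 2 gives 19000 nM. Going by the values given here, the single step so far, a 3.8-fold higher number from compound 1 to compound 2 (0.58 log units; beyond the scatter), is the only measured change in this group. Compound 2 thus stands at the higher of the two numbers, with compound 1 as its nearest neighbour at a lower number beyond the scatter.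

Compound 3 `NC(=S)Nc1cccc(OCCCCCOc2ccc(C(=O)O)cc2)c1` is not yet measured. It differs from compound 2 by carboxy in place of bromo on an aromatic carbon, the new group sitting para to a large group on the six-membered aromatic ring of carbon only. Among the compounds with values here, the one step that bears on this change, a 3.8-fold higher number from compound 1 to compound 2 (0.58 log units; beyond the scatter), concerns an exchange of one halogen for another and so does not cover the entry of a carboxy group. The data give no measured guide for such a change, so a step of modest size at most is expected, more likely upward, as a 1.3-fold higher number from compound 2 to compound 3 (0.12 log units; within the scatter). Compound 3 is therefore estimated at 25000 nM in this assay, with a range from 8000 nM to 80000 nM, pending the actual measurement.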

Compound 3, half-maximal cytotoxic concentration: > 50000 nM
Compound 3 ended at the assay's limit (the forecaster's own chance of this, stated with the estimate: 25%); middle value at least 2.0-fold (0.30 log units) from the limit.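

Compound 3 gives > 50000 nM in this assay, a limit of the assay and not a number, so what follows from it holds only as a lower bound: the limit of > 50000 nM in this assay, at which 1 of the 3 values shown sits.

The exchange of bromo for carboxy gives an at least 2.6-fold higher number from compound 2 to compound 3 (0.42 log units; beyond the scatter), and the exchange of fluoro for carboxy gives an at least 10-fold higher number from compound 1 to compound 3 (1.00 log units; beyond the scatter). Until now this place, on an aromatic carbon para to a large group, had shown only an exchange of one halogen for another, whereas these steps show that a group of another kind also moves the number beyond the scatter, and upward, with more compound tolerated than with either halogen.

Going by these compounds, how far the true value of compound 3 lies past the limit remains open, and with it the full size of both steps. On these data alone, it also remains open whether an amine, a methyl ester or a primary amide at this place would give a similar rise, and whether the rise seen with carboxy would persist with a longer chain in the shared core.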